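The source may hold more compounds than are shown below. What is called first, only, known or untested is meant among the compounds shown, and "the series" means these compounds.

Within the data shown here, in a physicochemical assay for lipophilicity, measured as octanol-water partition, at pH 7.4 (a higher number here means a more lipophilic compound, a lower number a more polar compound), compound 2 `N#Cc1ccc(N[C@H]2CC[C@H](N(C(=O)NCc3ccccc3)c3ccccc3)CC2)nc1` gives 3.3, the higher of the two numbers so far, while compound 1 `Cn1cc(-c2ccc(N(C(=O)NCc3ccccc3)[C@H]3CC[C@H](Nc4ccc(C#N)cn4)CC3)cc2)ccc1=O` gives 2.4. The next analogue, compound 3 `N#Cc1ccc(N[C@H]2CC[C@H](N(C(=O)NCc3ccccc3)c3ccc(-c4cccnc4)cc3)CC2)nc1`, carries pyridin-3-yl in place of hydrogen on an aromatic carbon, para to a large group (pyridin-3-yl in place of hydrogen on an aromatic carbon).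

Among the measured compounds shown here, only one measured step bears on this change: a number 0.90 log units higher from compound 1 to compound 2 (beyond the scatter), in which a hydrogen atom replaces a larger group containing a six-membered aromatic ring. Read backwards, this suggests that adding a ring at this kind of position could lower the number. However, the group in compound 1 is not pyridin-3-yl: it contains an oxygen and pyridin-3-yl does not. For the measured compounds named here, the drop behind a number 0.90 log units higher from compound 1 to compound 2 (beyond the scatter) therefore need not recur, and no measured compound carries pyridin-3-yl as a direct guide. With so little evidence, only a small rise is expected, and it may not clear the usual scatter: the expected change is a number 0.30 log units higher from compound 2 to compound 3 (within the scatter). For compound 3, the estimated value in this assay is 3.6, with an expected range of 3.1 to 4.1.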

Compound 3, distribution coefficient: 3
The estimate for compound 3 lay 0.60 log units above the measured number; measured number below the stated range.
By their numbers in this assay, from the lowest: compound 1; then compounds 3 and 2 (each within the scatter of the next).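

In this assay, placing pyridin-3-yl on this aromatic carbon in place of hydrogen gives a number 0.30 log units lower from compound 2 to compound 3 (within the scatter), so a second aromatic ring can sit at this position without a shift that stands clear of repeat measurements. The two compounds that carry a ring here still differ, with a number 0.60 log units higher from compound 1 to compound 3 (beyond the scatter), which shows that the gap first seen between hydrogen and the group in compound 1 does not come with every six-membered aromatic ring containing one hetero atom, and that the particular group matters at this position. No measurement shown here explains the gap between the group in compound 1 and pyridin-3-yl.

Only hydrogen and these two ring-bearing groups can be compared at this position, and pyridin-3-yl rests on a single pair, so no general rule follows for other rings or other cores. From the compounds shown here alone, it remains open how an amine, a carboxylic acid or a longer chain on the same aromatic carbon would read in this assay, and whether any of them would stay within the scatter of compound 2.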